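Swapping one chain end on a sulfonylguanidine in HeLa cells

A few compounds are considered here, and "the series" means these few. Any claim that something is new, unique, unknown or untested is made for them only; others in the source may bear on it.

Three close relatives of one sulfonylguanidine have been tested in a functional assay on HeLa cells (Homo sapiens) for antiproliferative activity, read by MTT assay, with a stated time of 72 h; on this read-out higher numbers stand for weaker inhibition and lower numbers for stronger inhibition. Compound 1 has the structure `Cc1cc(S(=O)(=O)/N=C(\N)N/N=C/C#Cc2ccccc2)c(SCc2ccc(Cl)cc2)cc1Cl`; in this assay compound 1 gives 6000 nM. Compound 2, with the structure `C/C(C#Cc1ccccc1)=N\N/C(N)=N/S(=O)(=O)c1cc(C)c(Cl)cc1SCc1ccc(Cl)cc1`, gives 8000 nM in this assay, and compound 3, with the structure `Cc1cc(S(=O)(=O)/N=C(\N)N/N=C/C#Cc2ccccc2)c(SCc2cccc3ccccc23)cc1Cl`, gives 8000 nM. The three numbers sit within the usual scatter of one another, so no order among them can be read.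

Compound 2 is compound 1 with a change on the chain that ends in the phenylethynyl arm: a group of 11 heavy atoms (10 carbon, 1 nitrogen; one six-membered aromatic ring of carbon only) in place of a group of 10 heavy atoms (9 carbon, 1 nitrogen; one six-membered aromatic ring of carbon only), on an amine nitrogen. That change made a 1.3-fold higher number from compound 1 to compound 2 (0.12 log units; within the scatter). Compound 3 keeps the chain of compound 1 but carries a different group on the sulfur side: naphthalen-1-yl in place of 4-chlorophenyl on a saturated chain carbon bound to a sulfur. That change made a 1.3-fold higher number from compound 1 to compound 3 (0.12 log units; within the scatter).

Compound 4, not yet measured, has the structure `C/C(C#Cc1ccccc1)=N\N/C(N)=N/S(=O)(=O)c1cc(C)c(Cl)cc1SCc1cccc2ccccc12`. It stands to compound 3 as compound 2 stands to compound 1: a group of 11 heavy atoms (10 carbon, 1 nitrogen; one six-membered aromatic ring of carbon only) in place of a group of 10 heavy atoms (9 carbon, 1 nitrogen; one six-membered aromatic ring of carbon only), on an amine nitrogen. The place of the change is described in the same words for both pairs, so this is the same change made on the core of compound 3 instead of the core of compound 1, the two cores differing as told above.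

Because the earlier change made a 1.3-fold higher number from compound 1 to compound 2 (0.12 log units; within the scatter), a step of about the same small size, a 1.3-fold higher number from compound 3 to compound 4 (0.10 log units; within the scatter), is expected here, and compound 4 is estimated to give 10000 nM, with a likely range from 5000 nM to 20000 nM.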

Compound 4, half-maximal inhibitory concentration: 125000 nM
Beside the measured number, compound 4's estimate is 13-fold (1.10 log units) below it; measured number outside the range, above it.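

In this assay, the swap to the group of 11 heavy atoms on the amine nitrogen does not keep on the core of compound 3 the size it had on the core of compound 1, giving a 16-fold higher number from compound 3 to compound 4 (1.19 log units; beyond the scatter): the same change on two cores in this assay, a 1.3-fold higher number (0.12 log units; within the scatter) from compound 1 to compound 2 and a 16-fold higher number (1.19 log units; beyond the scatter) from compound 3 to compound 4, 12-fold (1.07 log units) apart, beyond the scatter of two such steps

The same holds for naphthalen-1-yl in place of 4-chlorophenyl on a saturated chain carbon bound to a sulfur, which gives a 16-fold higher number from compound 2 to compound 4 (1.19 log units; beyond the scatter): the same change on two cores in this assay, a 1.3-fold higher number (0.12 log units; within the scatter) from compound 1 to compound 3 and a 16-fold higher number (1.19 log units; beyond the scatter) from compound 2 to compound 4, 12-fold (1.07 log units) apart, beyond the scatter of two such steps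

So each change alone leaves the number within the scatter, and only the two together, in compound 4, go with a much weaker result, which shows that in these four compounds the effect of one change depends on what sits at the other end, though it does not show why this happens or whether it holds beyond these four compounds.

Still open, from the compounds shown here alone, is whether the same large step appears with other groups on the saturated chain carbon bound to the sulfur, such as a plain phenyl or a 4-fluorophenyl, or with an ethyl group or a longer chain in the group on the amine nitrogen. Also open, going by these compounds, is how these pairs would behave in any read-out other than this assay.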